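Swapping a halogen on the amide's aryl ring

A few compounds are considered here, and "the series" means these few. Any claim that something is new, unique, unknown or untested is made for them only; others in the source may bear on it.

Compound 2 `Cc1ccc(C2=NOC(C)(C)C2=O)cc1-c1cnc(NC(=O)c2cc(F)ccc2F)cn1` carries a 2,5-difluorophenyl on its amide carbonyl carbon. In an assay on Jurkat T cells for inhibition of interleukin-2 (Homo sapiens), read by ELISA, with stated times of 10 min and 24 h (on this read-out higher numbers stand for weaker inhibition and lower numbers for stronger inhibition), compound 2 was reported as "not active" (no number reported), so no number marks where it stands, only that it showed no measurable inhibition. A related compound, compound 1 `COc1ccc(C2=NOC(C)(C)C2=O)cc1-c1cnc(NC(=O)c2c(F)cccc2F)cn1`, gives 50 nM in this assay, but it differs from compound 2 in two places at once, so its value cannot be tied to either difference alone.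

Compound 3 `Cc1ccc(C2=NOC(C)(C)C2=O)cc1-c1cnc(NC(=O)c2c(F)cccc2Cl)cn1` keeps everything of compound 2 except one part. The change is 2-chloro-6-fluorophenyl in place of 2,5-difluorophenyl on a carbonyl carbon. Among the measured compounds shown here, since compound 2 has no number, no step can be computed, and the direction can only be guessed. The most that can be said is that compound 3 could regain some inhibition or remain without it.

On that basis the expected value for compound 3 in this assay is 800 nM, with a range of 50 nM to 10000 nM, and a substantial chance that, like compound 2, it is again reported only as inactive.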

Compound 3, half-maximal inhibitory concentration: 64.8 nM
The estimate for compound 3 lay 12-fold (1.09 log units) above the measured number; the range from low to high includes it.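

In this assay, among the compounds shown here, compound 3 gives 64.8 nM while compound 2 has no number, so no step from compound 2 to compound 3 can be read. No other measurement here bears on this result. The compounds shown leave open how much of the inhibition seen for compound 3 goes with its 2-chloro-6-fluorophenyl group.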